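A Nitro for Methoxy Exchange on One Aromatic Carbon

The source may report more compounds than this note shows. Statements on the series, on what has been measured and on what is new or still open speak of the compounds shown alone.

Among the measured compounds shown here, in a functional assay on MIA PaCa-2 cells (Homo sapiens) for inhibition, read by MTT assay, with a stated time of 48 h, tested at 10 uM (a higher number here means more inhibition of growth at the concentration tested, a lower number less inhibition of growth), compound 1 `C#CCOc1ccc(/C=C/C(=O)c2ccc(Br)cc2)cc1` gives 34% and compound 2 `C#CCOc1ccc(/C=C/C(=O)c2ccc(OC)cc2)cc1` gives 32%, so compound 2 stands level with its only neighbour within the scatter. Compound 3 `C#CCOc1ccc(/C=C/C(=O)c2ccc([N+](=O)[O-])cc2)cc1` differs from compound 2 at a single site: nitro in place of methoxy on an aromatic carbon, with nitro in place of methoxy on an aromatic carbon, para to a large group. For the measured compounds named here, the one measured step at this site, a number 2 percentage points lower from compound 1 to compound 2 (within the scatter), exchanged bromo for methoxy and stayed within the scatter. No shift beyond the scatter is therefore expected in this assay, and the estimated step is a number 3 percentage points higher from compound 2 to compound 3 (within the scatter). The expected value for compound 3 is 35%, within a range of 23% to 49%.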

Compound 3, percent growth inhibition at one concentration: 42%
For compound 3 the middle estimate is 7 percentage points below the measured one; the range from low to high includes it.
By their numbers in this assay, from the lowest: compounds 2, 1 and 3 (each within the scatter of the next).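

In this assay the step to nitro reads a number 10 percentage points higher from compound 2 to compound 3 (within the scatter) and, against bromo, a number 8 percentage points higher from compound 1 to compound 3 (within the scatter) at this aromatic carbon. A third group at this site, with nitro bringing three heavy atoms and a double bond outside aromatic rings, thus still leaves all three compounds within the scatter of one another. No evidence bearing on this result is available.

From the compounds shown here alone, whether an amine or a carboxylic acid on this carbon would read beyond the scatter stays open. So does whether these exchanges would read alike on a different core.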